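The source may hold more compounds than are shown below. What is called first, only, known or untested is meant among the compounds shown, and "the series" means these compounds.

Compound 1 `CC(C)NC(=O)CC(c1ccc(-c2ccc3cccc(F)c3c2)[nH]c1=O)C(C)C`: 15 nM
Compound 2 `CC(C)C(Cc1ncc[nH]1)c1ccc(-c2ccc3cccc(F)c3c2)[nH]c1=O`: 76 nM
Compound 3 `CC(C)C(c1ncco1)c1ccc(-c2ccc3cccc(F)c3c2)[nH]c1=O`: 64 nM

In a functional assay on CHO cells for antagonist activity at prostaglandin E2 receptor EP3 subtype (Homo sapiens), read by cAMP accumulation (on this read-out higher numbers stand for weaker inhibition and lower numbers for stronger inhibition), compound 3 stands second highest of the three numbers: a 1.2-fold lower number from compound 2 to compound 3 (0.07 log units; within the scatter), while a 4.3-fold higher number from compound 1 to compound 3 (0.63 log units; beyond the scatter). Compound 4 `CC(C)C(c1ccc(-c2ccc3cccc(F)c3c2)[nH]c1=O)N1CCCCS1(=O)=O` has not yet been measured; it differs from compound 3 by a group of 8 heavy atoms (4 carbon, 1 nitrogen, 2 oxygen, 1 sulfur; one six-membered non-aromatic ring with 2 hetero atoms) in place of a group of 5 heavy atoms (3 carbon, 1 nitrogen, 1 oxygen; one five-membered aromatic ring with 2 hetero atoms), on a saturated chain carbon bound to an aromatic carbon and a saturated chain carbon. The most comparable measured step is a 4.3-fold higher number from compound 1 to compound 3 (0.63 log units; beyond the scatter), where a ring group at this carbon gave a higher number than the open amide of compound 1, and a 1.2-fold lower number from compound 2 to compound 3 (0.07 log units; within the scatter) shows two ring groups at this carbon sitting close together. The entering group is again a ring with hetero atoms, so only a small step is expected, a 1.7-fold higher number from compound 3 to compound 4 (0.24 log units; within the scatter), with some chance of a weaker result. Compound 4 is therefore estimated at 110 nM, within 35 nM to 400 nM.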

Compound 4, half-maximal inhibitory concentration: 122 nM
Compound 4: middle estimate off by 1.1-fold (0.04 log units), on the low side; low and high end bracket the measured number.
By their numbers in this assay, from the lowest: compound 1; then compounds 3, 2 and 4 (each within the scatter of the next).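

At the saturated chain carbon bound to an aromatic carbon and a saturated chain carbon, the six-membered non-aromatic ring of compound 4 reads level with both five-membered aromatic rings (a 1.9-fold higher number from compound 3 to compound 4 (0.28 log units; within the scatter); a 1.6-fold higher number from compound 2 to compound 4 (0.21 log units; within the scatter)), so aromaticity and ring size do not separate these three compounds. The open amide stays apart from this ring group too (an 8.1-fold higher number from compound 1 to compound 4 (0.91 log units; beyond the scatter)). Nothing measured here explains that gap.

Open, from the compounds shown here alone, is whether a carboxylic acid or a primary amide in place of the (isopropylcarbamoyl)methyl group would match compound 1. Also open, going by these compounds, is whether a longer chain between that carbon and the amide would.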